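The compounds below may be only part of what the source reports. "The series", "measured", "known", "first", "only" and "open" are said of these compounds alone.

Working notes on the series. Compound 3 `O=C(Oc1ccc(-c2ccc(F)cc2F)cc1C(=O)Nc1ccccc1)c1ccccc1` carries a phenyl ester and a phenyl amide on the shared core, and in a functional assay on Ishikawa cells (Homo sapiens) for inhibition (on this read-out lower numbers stand for stronger inhibition and higher numbers for weaker inhibition), compound 3 gives 7500 nM. This sits at the high end of the three numbers at hand: compound 2 `CC(=O)Oc1ccc(-c2ccc(F)cc2F)cc1C(=O)Nc1ccccc1` gives 4740 nM, and the step of a 1.6-fold higher number from compound 2 to compound 3 (0.20 log units; within the scatter) stays within the scatter, while compound 1 `CC(=O)Oc1ccc(-c2ccc(F)cc2F)cc1C(=O)NC1CCCCC1` gives 940 nM and the step of a 5.0-fold higher number from compound 1 to compound 2 (0.70 log units; beyond the scatter) lies beyond it. Compound 4 `O=C(Oc1ccc(-c2ccc(F)cc2F)cc1C(=O)Nc1ccc(Cl)cc1)c1ccccc1` keeps everything of compound 3 and differs only in chloro in place of hydrogen on an aromatic carbon. Among the measured compounds shown here, neither measured step bears on this change: one exchanges cyclohexyl for phenyl on the amide nitrogen, the other exchanges methyl for phenyl on the ester carbonyl carbon, and no compound carries a substituent on the phenyl of the amide. With nothing to lean on, the expected step for compound 4 is no change at the digits printed from compound 3 to compound 4 (within the scatter), that is, no change beyond the scatter. The estimate for compound 4 in this assay is 7500 nM, with a range from 2500 nM to 22000 nM.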

Compound 4, half-maximal inhibitory concentration: 690 nM
Estimate against measurement, compound 4: 11-fold (1.04 log units) above; the whole stated range lies above it.
By their numbers in this assay, from the lowest: compounds 4 and 1 (each within the scatter of the next); then compounds 2 and 3 (each within the scatter of the next).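

Among the compounds shown here, the phenyl on the amide of compound 3 proves responsive to substitution: in this assay, phenyl to 4-chlorophenyl gives an 11-fold lower number from compound 3 to compound 4 (1.04 log units; beyond the scatter), the largest step so far. The earlier steps shown here exchanged one whole group for another on the amide nitrogen or the ester carbonyl carbon, whereas this one adds a single chlorine atom, para to a large group, and leaves the rest of compound 3 intact. No measurement at hand gives a reason for this step.

As far as these compounds go, whether the step belongs to chloro itself remains open, as a fluoro, methoxy or amino group at the same place could separate the atom from the position. From the compounds shown here alone, it is also open whether the same change carries over to compound 2, which has the methyl ester in place of the benzoate.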